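Cyclopentyl in place of aryl on the amide carbonyl

The source may report more compounds than this note shows. Statements on the series, on what has been measured and on what is new or still open speak of the compounds shown alone.

Measured so far:
compound 1 `COc1ccc(C(=O)Nc2cc(-c3ccccc3)nn2-c2ccccc2)cc1` — in an assay on HEK293 cells for displacement of a labelled ligand from metabotropic glutamate receptor 5 (Rattus norvegicus) (a lower number here means a stronger inhibitor, a higher number a weaker inhibitor), compound 1 gives 420 nM
compound 2 `O=C(Nc1cc(-c2ccccc2)nn1-c1ccccc1F)c1ccccc1` — in this assay compound 2 gives 2700 nM
compound 3 `O=C(Nc1cc(-c2ccccc2)nn1-c1ccccc1Br)c1ccccc1` — in this assay compound 3 gives 2600 nM

Compound 1 stands lowest of the three numbers; compound 3 is nearest to it and compound 2 furthest, both gaps beyond the scatter. Within the data shown here, the one step between measured compounds, a 1.0-fold lower number from compound 2 to compound 3 (0.02 log units; within the scatter), concerns a substituent on the ring attached to the nitrogen of the shared core and leaves the carbonyl side untouched; it therefore says nothing about what follows.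

Compound 4 `O=C(Nc1cc(-c2ccccc2)nn1-c1ccccc1)C1CCCC1` differs from compound 1 at the carbonyl carbon: cyclopentyl in place of 4-methoxyphenyl on a carbonyl carbon. Among the measured compounds shown here, no measured pair shows this exchange, so the expectation rests on compound 1 as the only anchor, with wide uncertainty. Losing the aromatic ring with its acceptor at this position is expected to weaken binding rather than strengthen it, and the step is estimated as a 3.6-fold higher number from compound 1 to compound 4 (0.55 log units; beyond the scatter). Compound 4 is expected to give about 1500 nM in this assay, within a range from 400 nM to 6000 nM.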

Compound 4, inhibition constant: 11600 nM
Beside the measured number, compound 4's estimate is 7.7-fold (0.89 log units) below it, outside the stated range (above it).
By their numbers in this assay, from the lowest: compound 1; then compounds 3 and 2 (each within the scatter of the next); then compound 4.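

The group on the carbonyl carbon matters strongly in this assay: cyclopentyl in place of 4-methoxyphenyl on a carbonyl carbon gives a large step (a 28-fold higher number from compound 1 to compound 4 (1.44 log units; beyond the scatter)). Among these compounds, the only earlier step (a 1.0-fold lower number from compound 2 to compound 3 (0.02 log units; within the scatter)) lay in another place and stayed within the scatter, so this is the first measured sign of sensitivity at the carbonyl side. This single pair changes the aromatic ring, the ring size and the oxygen together, and no available measurement bears on the reason for the step.

As far as these compounds go, whether the loss follows the methoxy group or the aromatic ring stays open, and a plain phenyl on the carbonyl carbon of the core of compound 1 would separate the two. Also open, from the compounds shown here alone, is whether a cyclohexyl ring or an open butyl chain behaves like cyclopentyl.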